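Ortho substituent variation on the shared core

The compounds below may be only part of what the source reports. "The series", "measured", "known", "first", "only" and "open" are said of these compounds alone.

Measured compounds:
compound 1 `CC1(C)N=C(N)N=C(N)N1c1ccccc1N` — 4.11
compound 2 `CSc1ccccc1N1C(N)=NC(N)=NC1(C)C` — 3.54
compound 3 `CC1(C)N=C(N)N=C(N)N1c1ccccc1O` — 3.86

In an assay for inhibition of Dihydrofolate reductase (Bos taurus), at pH 6.25 (on this read-out higher numbers stand for higher potency (the scale is a negative logarithm) and lower numbers for lower potency), compound 2 gives the lowest of the three numbers: compound 3 sits a number 0.32 log units higher from compound 2 to compound 3 (beyond the scatter), and compound 1 sits a number 0.57 log units lower from compound 1 to compound 2 (beyond the scatter), both beyond the scatter. Compound 4 `CC1(C)N=C(N)N=C(N)N1c1ccccc1I` differs from compound 2 by iodo in place of methylsulfanyl on an aromatic carbon. Neither measured step replaces methylsulfanyl with a halogen, so the bearing steps are only indirect: exchanging methylsulfanyl for hydroxy or amino gave modest gains. No clear direction is therefore expected beyond the scatter; the estimated step is a number 0.16 log units higher from compound 2 to compound 4 (within the scatter). Compound 4 is expected to give 3.7 in this assay, between 3.3 and 4.2.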

Compound 4, logarithm of the reciprocal of the active concentration, log(1/C): 3.43
Estimate against measurement, compound 4: 0.27 log units above; the measured number falls inside the stated range.
By their numbers in this assay, from the lowest: compounds 4 and 2 (each within the scatter of the next); then compounds 3 and 1 (each within the scatter of the next).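

In this assay this position, on an aromatic carbon ortho to a large group, does not separate iodo from methylsulfanyl, with a number 0.11 log units lower from compound 2 to compound 4 (within the scatter) as the step. Iodo does separate from the other two groups, with a number 0.43 log units lower from compound 3 to compound 4 (beyond the scatter) and a number 0.68 log units lower from compound 1 to compound 4 (beyond the scatter) as its steps, so among these four compounds iodo and methylsulfanyl stand together below hydroxy and amino.

On these data alone, whether fluoro, chloro or methoxy would fall with iodo or with hydroxy remains open. Nothing available here accounts for this split into two groups of substituents.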